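The source may hold more compounds than are shown below. What is called first, only, known or untested is meant among the compounds shown, and "the series" means these compounds.

Measured compounds:
Compound 1, `CC(C)(C)c1cc(NC(=O)[C@@H]2CCCCN2CC2CCOCC2)no1`: 72 ug/mL
Compound 2, `CC(C)(C)c1cc(NC(=O)[C@@H]2CCCCN2C(=O)C2CCOCC2)no1`: 48 ug/mL
Compound 3, `CCC(=O)N1CCN(C(=O)N2CCCC[C@H]2C(=O)Nc2cc(C(C)(C)C)on2)CC1`: 68 ug/mL

These three numbers come from a physicochemical assay for solubility, read by HPLC, at pH 6.8; on this read-out lower numbers stand for lower solubility and higher numbers for higher solubility. All three share one core, and they differ only in the group attached to the ring nitrogen of that core. The three values sit close together: the gap between compound 1 and compound 3, and the gap between compound 2 and compound 3, are both within the usual scatter of this measurement, so no one of them can be called more or less soluble than the others.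

Compound 4, `CC(C)(C)c1cc(NC(=O)[C@@H]2CCCCN2C(=O)N2CC[S+]([O-])CC2)no1`, has not yet been measured in this assay. Compared with compound 3 it carries a group of 7 heavy atoms (4 carbon, 1 nitrogen, 1 oxygen, 1 sulfur; one six-membered non-aromatic ring with 2 hetero atoms) in place of a group of 10 heavy atoms (7 carbon, 2 nitrogen, 1 oxygen; one six-membered non-aromatic ring with 2 hetero atoms), on a carbonyl carbon.

Within the data shown here, two measured steps bear on this change. The step of a 1.5-fold lower number from compound 1 to compound 2 (0.18 log units; within the scatter) swapped one ring-bearing group for another on the same nitrogen, and the step of a 1.4-fold higher number from compound 2 to compound 3 (0.15 log units; within the scatter) swapped one ring for another on the same carbonyl carbon. Neither moved the number beyond the scatter. The change to compound 4 is of the same kind, a ring for a ring on that carbonyl carbon, so the expected step of a 1.2-fold higher number from compound 3 to compound 4 (0.07 log units; within the scatter) is small, with no clear direction. Compound 4 is therefore estimated at 80 ug/mL, within a range of 35 ug/mL to 180 ug/mL.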

Compound 4, solubility: 68 ug/mL
Compound 4: middle estimate off by 1.2-fold (0.07 log units), on the high side; the measured number falls inside the stated range.
By their numbers in this assay, from the lowest: compounds 2, 3, 4 and 1 (each within the scatter of the next).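

The group that enters on the carbonyl carbon is a six-membered non-aromatic ring holding sulfur, a kind of atom absent from the earlier groups, and in this assay it gives no change at the digits printed from compound 3 to compound 4 (within the scatter). Set against the oxan-4-yl group on the same carbonyl carbon, it gives a 1.4-fold higher number from compound 2 to compound 4 (0.15 log units; within the scatter), and the whole substituent on the ring nitrogen, set against (oxan-4-yl)methyl, gives a 1.1-fold lower number from compound 1 to compound 4 (0.02 log units; within the scatter). These steps extend the picture to a sulfur-bearing ring, with every one of them inside the scatter, and no supporting measurement is available to explain this flat result.

The compounds shown all carry a ring-bearing group at this position, so it remains open whether a group of a different type, such as a carboxylic acid or an open-chain amine on the carbonyl carbon, would move the number beyond the scatter. Also open, on these data alone, is whether the flat readings hold when the rest of the shared core changes, for example if a smaller alkyl chain replaces its tert-butyl group.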